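Oxime-linked biphenyl diacids with aryl ether tails

A few compounds are considered here, and "the series" means these few. Any claim that something is new, unique, unknown or untested is made for them only; others in the source may bear on it.

Measured so far:
compound 1 `CCCCCCCCCCOc1cccc(OCCCCCCON=C(c2ccc(C(=O)O)cc2)c2ccc(C(=O)O)cc2)c1` – "not determined" (no result reported) in an assay on isolated protein for binding affinity to L-selectin (Homo sapiens), read by ELISA, tested at 500 uM; a higher number here means more inhibition at the concentration tested (going by the name of the read-out), a lower number less inhibition
compound 2 `CCCCCCCCCCOc1cc(OCCCCCCCCCC)cc(OCCCCCCN(Cc2ccc(C(=O)O)cc2)c2ccc(C(=O)O)cc2)c1` – "not determined" (no result reported) in this assay
compound 3 `O=C(O)c1ccc(N(C(=O)CCCCCBr)c2ccc(C(=O)O)cc2)cc1` – 6%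

Among the compounds with values here, compound 1 has no number in this assay, its entry reading "not determined" (no result reported), and compound 2 likewise gives "not determined" (no result reported); compound 3 is the only compound with a read-out, where compound 3 gives 6%. Compound 1 therefore stands nowhere on the numbers shown, and no step between measured compounds exists to anchor it.

Compound 4 `CCCCCCCCCCOc1cc(OCCCCCCCCCC)cc(OCCCCCCON=C(c2ccc(C(=O)O)cc2)c2ccc(C(=O)O)cc2)c1` differs from compound 1 by decyloxy in place of hydrogen on an aromatic carbon. Within the data shown here, with no measured pair for this change, the expected step in this assay cannot be sized from the data; any direction is open, and a step within the scatter is as plausible as one beyond it.

Compound 4 is expected to give 30%, with a range from 0% to 70%.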

Compound 4, a percentage reported as inhibition, at one concentration (the size of the read-out at that concentration, not a potency): 6%
The estimate for compound 4 lay 24 percentage points above the measured number; the range from low to high includes it.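

In this assay, within the data shown here, compound 1 carries no number and no step to compound 4 can be read. No measured evidence bears on this result. On these data alone, whether the added decyloxy changes the read-out at all stays open.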